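A few compounds are considered here, and "the series" means these few. Any claim that something is new, unique, unknown or untested is made for them only; others in the source may bear on it.

The measured compounds so far:
compound 1, `Cc1cccc(NC(=O)N[C@H](C)c2ccccc2)c1`, gives 98%
compound 2, `Cc1cccc(NC(=O)N[C@@H](C)c2ccccc2)c1`, gives 100%
compound 3, `Cc1ccc(NC(=O)N[C@H](C)c2ccccc2)cc1`, gives 98%

All three were tested in an ADME assay on the whole organism with Oryza sativa as the target, tested at 1 uM; a higher number here means a weaker effect of the compound at the concentration tested, a lower number a stronger effect. Compound 1 stands level with compound 3 at the digits shown, and the two together are the lowest of the three numbers; compound 2 lies a number 2 percentage points higher from compound 1 to compound 2 (within the scatter), which is within the scatter. Among the measured compounds shown here, that one step is the only measured step between compounds differing in a single place, and it is small because of the fact that compounds 1 and 2 differ only in the configuration as drawn.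

The next compound is compound 4, `CCc1cccc(NC(=O)N[C@H](C)c2ccccc2)c1`. It differs from compound 1 by methyl in place of hydrogen on a saturated chain carbon bound to an aromatic carbon. For the measured compounds named here, no measured step touches this kind of change: the only measured step, the configurational one, stayed within the scatter, and nothing among the measured compounds speaks to a methyl to ethyl change. Compound 1 already stands near the top of the scale in this assay, so there is little room for a higher number. The writer therefore expects no step beyond the scatter for compound 4, that is a number 1 percentage points lower from compound 1 to compound 4 (within the scatter). For compound 4 the estimated value in this assay is 97%, with a range from 85% to 100%.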

Compound 4, a percentage reported as activity, at one concentration (the size of the read-out at that concentration, not a potency): 71%
Estimate against measurement, compound 4: 26 percentage points above, and the stated range ends above it.
By their numbers in this assay, from the lowest: compound 4; then compounds 1, 3 and 2 (each within the scatter of the next).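

In this assay methyl in place of hydrogen on a saturated chain carbon bound to an aromatic carbon gives a number 27 percentage points lower from compound 1 to compound 4 (beyond the scatter) and so shows that the read-out responds to a change at this place. Among the compounds shown here, this is the first step that lies beyond the scatter, whereas the change of configuration from compound 1 to compound 2 stayed within it, and here a single added carbon, methyl to ethyl, is enough. Nothing at hand accounts for the size of this step.

The compounds shown leave open whether a longer chain such as propyl, or an amine, at this place would carry the step further, hold it or reverse it. They also leave open whether the other drawn configuration of compound 4 would give the same number.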